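Sulfamoyl for methylsulfonyl: a paired comparison

The source may hold more compounds than are shown below. What is called first, only, known or untested is meant among the compounds shown, and "the series" means these compounds.

Measured in a functional assay on B16-F10 cells (Mus musculus) for antiproliferative activity, read by MTT assay, with a stated time of 72 h; a lower number here means a stronger inhibitor, a higher number a weaker inhibitor:
- compound 1, `CC(=O)Oc1ccc(/C=C/C(=O)OCCSc2nc(-c3ccc(S(C)(=O)=O)cc3)n(-c3ccc(F)cc3)n2)cc1OC(C)=O`: compound 1 gives 14200 nM
- compound 2, `CC(=O)Oc1ccc(/C=C/C(=O)OCCSc2nc(-c3ccc(S(N)(=O)=O)cc3)n(-c3ccc(F)cc3)n2)cc1OC(C)=O`: compound 2 gives 11000 nM
- compound 3, `CS(=O)(=O)c1ccc(-c2nc(SCCOC(=O)/C=C/c3ccc(O)c(O)c3)nn2-c2ccccc2)cc1`: compound 3 gives 15000 nM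

Compound 1 and compound 2 share one core and differ in a single place, (amino in place of methyl on a sulfonyl sulfur). The step is a 1.3-fold lower number from compound 1 to compound 2 (0.11 log units; within the scatter).

Compound 3 sits on a different core; the difference between the two cores is not broken down here. Against compound 1 and compound 2, the value of compound 3 lies within the scatter of both, so no order among the three is stated.

Compound 4, `NS(=O)(=O)c1ccc(-c2nc(SCCOC(=O)/C=C/c3ccc(O)c(O)c3)nn2-c2ccccc2)cc1`, has not yet been measured. It stands to compound 3 as compound 2 stands to compound 1: amino in place of methyl on a sulfonyl sulfur. The place is described in the same words in both pairs, on a sulfonyl sulfur whose other neighbours are aromatic carbon, so the change is taken as the same, not merely of the same kind.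

The step expected here is a 1.3-fold lower number from compound 3 to compound 4 (0.10 log units; within the scatter), because the same change on the other core gave a 1.3-fold lower number from compound 1 to compound 2 (0.11 log units; within the scatter). Among the measured compounds shown here, only one prior instance exists, so the expectation is weakly founded and is kept within the scatter.

For compound 4 the estimate in this assay is 12000 nM, expected between 6000 nM and 25000 nM.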

Compound 4, half-maximal inhibitory concentration: 15000 nM
The estimate for compound 4 lay 1.3-fold (0.10 log units) below the measured number; the measured number falls inside the stated range.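

In this assay, exchanging methylsulfonyl for sulfamoyl gives no change at the digits printed from compound 3 to compound 4 (within the scatter) in the second pair. Set beside the earlier pair, the same exchange gives steps on the two cores that cannot be told apart: the same change on two cores in this assay, a 1.3-fold lower number (0.11 log units; within the scatter) from compound 1 to compound 2 and no change at the digits printed (within the scatter) from compound 3 to compound 4, 1.3-fold (0.11 log units) apart, within the scatter of two such steps

This shows that, in these two pairs, the exchange moves the number by no more than the scatter on either core, so 4-(methylsulfonyl)phenyl and 4-sulfamoylphenyl cannot be separated in this read-out. It does not show that the exchange has a real effect of shared size or direction, and two pairs within the scatter offer no basis for a rule covering other cores in the series.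

The compounds shown leave open whether a group other than these two, such as a carboxylic acid or a nitrile in place of the sulfonyl group, would give a step beyond the scatter. Among the compounds shown here, they also leave open what separate contributions the acetyl esters and the fluorine make, since these features occur together on the core of compound 1 and no single-place pair isolates either one.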